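Naphthalenyl for propyl on the amidine benzamide scaffold

A few compounds are considered here, and "the series" means these few. Any claim that something is new, unique, unknown or untested is made for them only; others in the source may bear on it.

Compound 2 `CCCC(NC(=O)c1ccc(C(=N)N)cc1)C(C)(C)C(=O)N1CCC(CC(=O)O)CC1` gives 0.9 h in an in vivo ADME assay on the whole organism (Cavia porcellus); on this read-out higher numbers stand for a longer-lived compound and lower numbers for a shorter-lived compound. Compound 1 `CCC(NC(=O)c1ccc(C(=N)N)cc1)C(C)(C)C(=O)N1CCC(CC(=O)O)CC1` gives 1.3 h and compound 3 `CCCCC(NC(=O)c1ccc(C(=N)N)cc1)C(C)(C)C(=O)N1CCC(CC(=O)O)CC1` gives 1.03 h, and compound 2 lies within the scatter of both: a 1.4-fold lower number from compound 1 to compound 2 (0.16 log units; within the scatter), a 1.1-fold higher number from compound 2 to compound 3 (0.06 log units; within the scatter) and a 1.3-fold lower number from compound 1 to compound 3 (0.10 log units; within the scatter). Compound 4 `CC(C)(C(=O)N1CCC(CC(=O)O)CC1)C(NC(=O)c1ccc(C(=N)N)cc1)c1ccc2ccccc2c1` differs from compound 2 by naphthalen-2-yl in place of propyl on a saturated chain carbon bound to an amide-type nitrogen and a saturated chain carbon. Among the measured compounds shown here, the measured steps all exchange hydrogen for methyl or ethyl on the saturated chain; none of them replaces an alkyl group with a ring system, so no measured step bears directly on this change, and the known steps give no ground to expect a step beyond the scatter. Compound 4 is therefore expected to give 1 h, between 0.4 h and 2.5 h, a step of a 1.1-fold higher number from compound 2 to compound 4 (0.05 log units; within the scatter).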

Compound 4, half-life: 0.85 h
Estimate against measurement, compound 4: 1.2-fold (0.07 log units) above; low and high end bracket the measured number.
By their numbers in this assay, from the lowest: compounds 4, 2, 3 and 1 (each within the scatter of the next).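

Until now this saturated chain carbon, bound to an amide-type nitrogen and a saturated chain carbon, had carried only alkyl chains. Compound 4 shows that naphthalen-2-yl, with its 2 six-membered aromatic rings of carbon only, also stays within the scatter in this assay against all three alkyl compounds (a 1.1-fold lower number from compound 2 to compound 4 (0.02 log units; within the scatter)) (a 1.2-fold lower number from compound 3 to compound 4 (0.08 log units; within the scatter)) (a 1.5-fold lower number from compound 1 to compound 4 (0.18 log units; within the scatter)). Nothing at hand accounts for this result. The compounds shown leave open whether a phenyl ring, or a naphthalen-2-yl ring bearing an amine or a carboxylic acid, would also stay within the scatter here.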